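The source may report more compounds than this note shows. Statements on the series, on what has been measured and on what is new or still open speak of the compounds shown alone.

Compound 3 `CC1CCCC(C(=O)N2CCc3nc(C#Cc4ccccc4)sc3C2)C1` carries an amide whose carbonyl carbon bears a 3-methylcyclohexyl group. In an assay on HEK293 cells for negative allosteric modulation of metabotropic glutamate receptor 5 (Homo sapiens), read by FLIPR, with a stated time of 1 h (on this read-out lower numbers stand for stronger inhibition and higher numbers for weaker inhibition), compound 3 gives > 10000 nM, which is a limit of the assay rather than a measured number. The two related compounds stand in the same place. Compound 1 `CN1CCc2nc(C#Cc3ccccc3)sc2C1`, with a methyl on the ring nitrogen, gives > 10000 nM in this assay, also a limit. Compound 2 `CC1CC(C(=O)N2CCc3nc(C#Cc4ccccc4)sc3C2)C1` gives > 10000 nM in this assay, a limit as well. Because the limit of > 10000 nM in this assay, at which 3 of the 3 values shown sit, holds every value shown, neither a step that the two limits leave unreadable from compound 1 to compound 2 nor a step that the two limits leave unreadable from compound 2 to compound 3 can be read in size or direction; none of the three structures reached a measurable number.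

Compound 4 `O=C(C1CCOCC1)N1CCc2nc(C#Cc3ccccc3)sc2C1` differs from compound 3 by oxan-4-yl in place of 3-methylcyclohexyl on a carbonyl carbon. Among the measured compounds shown here, no measured step shows what an oxygen-containing ring does here, so the only guide is that every neighbour of compound 4 sits at the limit. Compound 4 is therefore expected to give 15000 nM in this assay, most likely again only as a limit, with a plausible range from 3000 nM to 100000 nM. The expected step that the limit leaves unreadable from compound 3 to compound 4 is no change beyond the scatter.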

Compound 4, half-maximal inhibitory concentration: > 10000 nM
Compound 4: only a limit was reported; the forecaster's own chance of this, stated with the estimate: 85%; the middle value is on the limit's open side.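

In this assay compound 4 gives > 10000 nM as a limit of the assay. Among the compounds shown here, no step among compound 1, compound 2, compound 3 and compound 4 can be read in size or direction, because all share one limit: the limit of > 10000 nM in this assay, at which 4 of the 4 values shown sit. The compounds shown leave open whether any group on the carbonyl carbon of the shared core gives a measurable value.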